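From methoxy to bromo: compound 3 to compound 4

This account rests on a few compounds, and the source may have more. Where it says the series, first, only, none or still open, it means among the compounds named here.

Measured in a functional assay on A549 cells (Homo sapiens) for cytotoxicity, read by MTT assay, with a stated time of 72 h; a higher number here means a weaker inhibitor, a lower number a stronger inhibitor:
- Compound 1 `CNC(=O)c1cc(Oc2ccc(C3=NNC(c4cccc(Br)c4)C3)cc2)ccn1`: 2840 nM
- Compound 2 `CNC(=O)c1cc(Oc2ccc(C3=NNC(c4ccc([N+](=O)[O-])cc4)C3)cc2)ccn1`: 19500 nM
- Compound 3 `CNC(=O)c1cc(Oc2ccc(C3=NNC(c4ccc(OC)cc4)C3)cc2)ccn1`: 13100 nM

Compound 3 sits among the higher numbers of this small set. The step of a 1.5-fold lower number from compound 2 to compound 3 (0.17 log units; within the scatter) leaves it level with the nitro compound, while the step of a 4.6-fold higher number from compound 1 to compound 3 (0.66 log units; beyond the scatter) sets it clearly apart from the 3-bromophenyl compound.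

Compound 4 `CNC(=O)c1cc(Oc2ccc(C3=NNC(c4ccc(Br)cc4)C3)cc2)ccn1` carries bromo in place of methoxy on an aromatic carbon, para to a large group (bromo in place of methoxy on an aromatic carbon). Among the compounds with values here, no measured step makes exactly this change. The nearest is the step of a 4.6-fold higher number from compound 1 to compound 3 (0.66 log units; beyond the scatter), but it also moves the bromo, so only part of its size can be expected to carry over. The step of a 6.9-fold higher number from compound 1 to compound 2 (0.84 log units; beyond the scatter) is of similar size and points the same way. The step of a 1.5-fold lower number from compound 2 to compound 3 (0.17 log units; within the scatter) shows that one exchange at this place stayed within the scatter, which argues against a large move. A modest step towards a lower number is therefore expected.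

For compound 4 the estimated value is 6000 nM, with an expected range from 2500 nM to 14000 nM. The expected change is a 2.2-fold lower number from compound 3 to compound 4 (0.34 log units; beyond the scatter).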

Compound 4, half-maximal inhibitory concentration: 21000 nM
Compound 4: the middle estimate sits 3.5-fold (0.54 log units) below what was measured; the whole stated range lies below it.
By their numbers in this assay, from the lowest: compound 1; then compounds 3, 2 and 4 (each within the scatter of the next).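

In this assay, the step of a 1.6-fold higher number from compound 3 to compound 4 (0.20 log units; within the scatter) shows that bromo in place of methoxy on this aromatic carbon, para to a large group, brings no change beyond the scatter, and the step of a 1.1-fold higher number from compound 2 to compound 4 (0.03 log units; within the scatter) shows the same for bromo in place of nitro, so the 4-methoxyphenyl, 4-nitrophenyl and 4-bromophenyl compounds all read as level. The bromo alone therefore does not go with the lower number of compound 1: the step of a 7.4-fold higher number from compound 1 to compound 4 (0.87 log units; beyond the scatter) separates two compounds that both carry a bromo, and the change is 4-bromophenyl in place of 3-bromophenyl, which leaves compound 1 as the only one of the four that stands apart. Nothing in the data gives a reason for this difference.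

The compounds shown leave open whether an amine or a carboxylic acid on the same aromatic carbon would also read level with these three. They also leave open whether methoxy or nitro, set where compound 1 carries its bromo, would keep a number close to that of compound 1.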